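Bromo in Place of Hydrogen on Two Related Cores

A few compounds are considered here, and "the series" means these few. Any claim that something is new, unique, unknown or untested is made for them only; others in the source may bear on it.

Compound 1 `O=[N+]([O-])c1ccc(Cl)c(/C=C/c2nc3ncccc3[nH]2)c1` and compound 2 `O=[N+]([O-])c1ccc(Cl)c(/C=C/c2nc3ncc(Br)cc3[nH]2)c1` share one core, compound 2 differing by bromo in place of hydrogen on an aromatic carbon. In a functional assay on MIA PaCa-2 cells (Homo sapiens) for antiproliferative activity, read by MTT assay, with a stated time of 72 h (on this read-out lower numbers stand for stronger inhibition and higher numbers for weaker inhibition), compound 1 gives 38800 nM, while compound 2 gives 30600 nM; the step is a 1.3-fold lower number from compound 1 to compound 2 (0.10 log units; within the scatter). Compound 3 `N#Cc1ccc(/C=C/c2nc3ncccc3[nH]2)cc1` carries a second core; the difference between the two cores is not broken down here. In this assay compound 3 reaches only a limit, > 100000 nM, as described by the limit of > 100000 nM in this assay, at which 1 of the 3 values shown sits. Compound 4 `N#Cc1ccc(/C=C/c2nc3ncc(Br)cc3[nH]2)cc1` differs from compound 3 by the same change, (bromo in place of hydrogen on an aromatic carbon), and awaits measurement in this assay. Resting on the step of a 1.3-fold lower number from compound 1 to compound 2 (0.10 log units; within the scatter), compound 4 is expected to give about 100000 nM, between 45000 nM and 300000 nM. That amounts to an expected step of a number no higher from compound 3 to compound 4 (the limit leaves the size open), with a fair chance this assay again reports only a limit.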

Compound 4, half-maximal inhibitory concentration: 8170 nM
For compound 4 the middle estimate is 12-fold (1.09 log units) above the measured one; measured number below the stated range.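

In this assay, bromo in place of hydrogen gives an at least 12-fold lower number from compound 3 to compound 4 (1.08 log units; beyond the scatter). The same change therefore does not carry over from one core to the other with the same size: the same change on two cores in this assay, a 1.3-fold lower number (0.10 log units; within the scatter) from compound 1 to compound 2 and an at least 12-fold lower number (1.08 log units; beyond the scatter) from compound 3 to compound 4, at least 9.6-fold (0.98 log units) apart, beyond the scatter of two such steps. For compound 3 the assay gives only a limit, > 100000 nM, and two cores show neither why the steps differ nor how the change would behave on a third core.

The compounds shown leave open whether another group on that aromatic carbon, such as fluoro, methyl or an amine, would follow bromo on either core. They also leave open whether a different group on the other ring would alter the size of the bromo step.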